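Hydrazone aryl swap: from halogenated phenyl to 3-hydroxyphenyl

A few compounds are considered here, and "the series" means these few. Any claim that something is new, unique, unknown or untested is made for them only; others in the source may bear on it.

Measured so far:
compound 1 `Cn1c(=O)c(=O)n(C2CCCC2)c2nc(N/N=C/c3ccc(S(C)(=O)=O)cc3)ncc21`: 26600 nM
compound 2 `Cn1c(=O)c(=O)n(C2CCCC2)c2nc(N/N=C/c3ccc(F)cc3Cl)ncc21`: 15200 nM

In a functional assay on PC-3 cells (Homo sapiens) for antiproliferative activity, read by MTT assay (a higher number here means a weaker inhibitor, a lower number a stronger inhibitor), compound 1 gives 26600 nM and compound 2 gives 15200 nM. Among the compounds with values here, the single step so far, a 1.8-fold lower number from compound 1 to compound 2 (0.24 log units; within the scatter), leaves compound 2 and compound 1 indistinguishable within the scatter, so compound 2 stands level with compound 1 on these two numbers.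

Compound 3 `Cn1c(=O)c(=O)n(C2CCCC2)c2nc(N/N=C/c3cccc(O)c3)ncc21` differs from compound 2 by 3-hydroxyphenyl in place of 2-chloro-4-fluorophenyl on a carbon with a double bond to nitrogen. Within the data shown here, the one measured step concerns the same carbon and was within the scatter; no step with a hydroxyl-bearing aryl exists here. No change beyond the scatter is therefore expected in this assay, the step from compound 2 to compound 3 being estimated as a 1.3-fold higher number from compound 2 to compound 3 (0.12 log units; within the scatter). For compound 3 the estimate is 20000 nM, within the range 6000 nM to 70000 nM.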

Compound 3, half-maximal inhibitory concentration: 36300 nM
Beside the measured number, compound 3's estimate is 1.8-fold (0.26 log units) below it; the range from low to high includes it.
By their numbers in this assay, from the lowest: compounds 2, 1 and 3 (each within the scatter of the next, the first and the last beyond it).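

In this assay, this position gives its first step beyond the scatter, a modest one (a 2.4-fold higher number from compound 2 to compound 3 (0.38 log units; beyond the scatter)), with 3-hydroxyphenyl replacing 2-chloro-4-fluorophenyl. The same group replacing 4-(methylsulfonyl)phenyl stays within the scatter (a 1.4-fold higher number from compound 1 to compound 3 (0.14 log units; within the scatter)), so the aryl swap on this carbon separates only compound 2 and compound 3. No available evidence bears on this difference.

The hydroxyl and the loss of chlorine and fluorine change together here, leaving open which of them carries the step. Going by these compounds, how a phenyl bearing an amine or a carboxylic acid would compare also remains open.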